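Series notes: thiazolyl ketone sulfides against U-87 MG cells

A few compounds are considered here, and "the series" means these few. Any claim that something is new, unique, unknown or untested is made for them only; others in the source may bear on it.

Measured so far:
compound 1 `COc1ccc(-c2nc(SCC(=O)c3sc(-c4ccccc4)nc3C)nc(N)c2C#N)cc1` — 17.2%
compound 2 `Cc1nc(-c2ccc(Cl)cc2)sc1C(=O)CSc1nc(-c2ccccc2)c(C#N)c(=O)[nH]1` — 11.4%
compound 3 `COc1ccc(-c2nc(C)c(C(=O)CSc3nc(-c4ccc(OC)c(OC)c4)c(C#N)c(=O)[nH]3)s2)cc1` — 5.39%

All three were tested in a functional assay on U-87MG ATCC cells for antiproliferative activity against U-87 MG (Homo sapiens), read by MTT assay, with a stated time of 48 h, tested at 100 uM; a higher number here means a weaker effect of the compound at the concentration tested, a lower number a stronger effect. Compound 1 gives 17.2%, compound 2 gives 11.4% and compound 3 gives 5.39%. Compound 2 sits second highest of the three numbers; its nearest neighbour is compound 1, whose number is higher by an amount within the scatter, and the furthest is compound 3, whose number is lower by an amount that is also within the scatter. On these numbers the three compounds cannot be told apart.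

The next compound, compound 4 `Cc1nc(-c2ccc(Cl)cc2)sc1C(=O)CSc1nc(-c2ccc(Cl)c(Cl)c2)c(C#N)c(=O)[nH]1`, has not yet been measured. It differs from compound 2 in one place: 3,4-dichlorophenyl in place of phenyl on an aromatic carbon.

Among the compounds with values here, no step between two measured compounds is available that isolates this kind of change, so there is no measured guide for its size. Given that the three measured compounds all lie within the scatter of one another, no step beyond the scatter is expected in this assay in either direction. The expected step from compound 2 is a number 0.6 percentage points higher from compound 2 to compound 4 (within the scatter). Compound 4 is thus estimated at 12%, with a range from 3% to 26%.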

Compound 4, a percentage reported as activity, at one concentration (the size of the read-out at that concentration, not a potency): 36.5%
For compound 4 the middle estimate is 24.5 percentage points below the measured one; the measured number lies above the stated range.
By their numbers in this assay, from the lowest: compounds 3, 2 and 1 (each within the scatter of the next, the first and the last beyond it); then compound 4.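

In this assay, within the data shown here, 3,4-dichlorophenyl in place of phenyl gives a number 25.1 percentage points higher from compound 2 to compound 4 (beyond the scatter), the first step that isolates a single change. At this aromatic carbon, ortho to a cyano group and next to the ring nitrogen, the substituent therefore matters: with the rest of compound 2 held constant, the chlorines on the phenyl go with a weaker effect at the concentration tested. No measurement that bears on the origin of this step is available.

This single pair does not show whether both chlorines are needed for the step, or whether it would carry over to a different substitution elsewhere on the shared core. It also leaves open how this position would respond to a phenyl bearing an amine or a carboxylic acid, and since the read-out comes from one concentration, the step describes the size of the effect at that concentration and not a change in potency.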